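The compounds below may be only part of what the source reports. "The series", "measured", "known", "first", "only" and "open" are said of these compounds alone.

Compound 1 `Nc1nn(C(=O)Nc2ccc(Cc3ccccc3)cc2)c2ccccc12` gives > 100000 nM in a functional assay on SF-268 cells (Homo sapiens) for antiproliferative activity, read by sulforhodamine B assay, with a stated time of 48 h (a lower number here means that less compound is tolerated, a higher number that more compound is tolerated), and this is a limit of the assay rather than a number. Compound 2 `Nc1nn(C(=O)Nc2ccc(Cc3ccccc3)cc2)c2ccc(Cl)cc12` gives > 100000 nM in this assay, again only a limit. The step that the two limits leave unreadable from compound 1 to compound 2 is therefore not readable in size or direction; the limit of > 100000 nM in this assay, at which 2 of the 2 values shown sit, marks where both values sit. Compound 3 `Nc1ccc2c(c1)c(N)nn2C(=O)Nc1ccc(Cc2ccccc2)cc1` differs from compound 2 by amino in place of chloro on an aromatic carbon. For the measured compounds named here, no measured step bears on this change. Compound 3 is expected to remain near the same limit, with an estimated step that the limit leaves unreadable from compound 2 to compound 3 not beyond the scatter. The estimate for compound 3 is 150000 nM, with a range from 50000 nM to 500000 nM.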

Compound 3, concentration lethal to 50% of the cells: 72500 nM
For compound 3 the middle estimate is 2.1-fold (0.32 log units) above the measured one; the range from low to high includes it.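

In this assay, for the compounds shown here, amino in place of chloro on this aromatic carbon gives a number where the earlier compounds gave only a limit: the limit of > 100000 nM in this assay, at which 2 of the 3 values shown sit. The change from chloro gives an at least 1.3-fold lower number from compound 2 to compound 3 (0.13 log units; that floor lies within the scatter), and the change from hydrogen at the same place gives an at least 1.3-fold lower number from compound 1 to compound 3 (0.13 log units; that floor lies within the scatter). Going by these compounds, both are floors, so the true size of each step remains unknown, and neither shows a change beyond the scatter.

Whether this response is particular to amino remains open, as the compounds shown do not include a hydroxyl or acetamido group at this place.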